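From 4-fluorobenzyl to 2,6-dichlorobenzyl: a small step expected

A few compounds are considered here, and "the series" means these few. Any claim that something is new, unique, unknown or untested is made for them only; others in the source may bear on it.

Compound 1 `Cc1ccccc1CN1CCN(C(=O)CN[C@H]2CCN(S(=O)(=O)Cc3ccccc3)C2)CC1`: 10200 nM
Compound 2 `O=C(CN[C@H]1CCN(S(=O)(=O)Cc2ccccc2)C1)N1CCN(Cc2cccc(F)c2)CC1`: 13200 nM
Compound 3 `O=C(CN[C@H]1CCN(S(=O)(=O)Cc2ccccc2)C1)N1CCN(Cc2ccc(F)cc2)CC1`: 14300 nM

In a functional assay on K562 cells (Homo sapiens) for cytotoxicity, read by MTT assay, with a stated time of 48 h (on this read-out lower numbers stand for stronger inhibition and higher numbers for weaker inhibition), compound 3 gives 14300 nM, a value within the usual scatter of those of the other two compounds. The next compound to be tested, compound 4 `O=C(CN[C@H]1CCN(S(=O)(=O)Cc2ccccc2)C1)N1CCN(Cc2c(Cl)cccc2Cl)CC1`, keeps the shared core and changes one group: 2,6-dichlorophenyl in place of 4-fluorophenyl on a saturated chain carbon bound to an amine nitrogen in a ring. Put simply, 2,6-dichlorophenyl stands in place of 4-fluorophenyl on a saturated chain carbon bound to an amine nitrogen in a ring.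

Going by the values given here, three measured steps concern this same place: a 1.3-fold higher number from compound 1 to compound 2 (0.11 log units; within the scatter), a 1.4-fold higher number from compound 1 to compound 3 (0.15 log units; within the scatter) and a 1.1-fold higher number from compound 2 to compound 3 (0.03 log units; within the scatter). None of them leaves the scatter. Among the compounds with values here, still, no measured compound carries chlorine, so these steps are only indirect evidence for compound 4. No step beyond the scatter is expected in this assay, and the data favour no clear direction. The estimated change is a 1.2-fold lower number from compound 3 to compound 4 (0.08 log units; within the scatter). The expected value for compound 4 is 12000 nM. The estimated range runs from 6000 nM to 24000 nM.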

Compound 4, half-maximal inhibitory concentration: 28400 nM
Compound 4: middle estimate off by 2.4-fold (0.37 log units), on the low side, and the stated range ends below it.
By their numbers in this assay, from the lowest: compounds 1, 2, 3 and 4 (each within the scatter of the next, the first and the last beyond it).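

In this assay this position had shown no step beyond the scatter until the 2,6-dichlorobenzyl group of compound 4, which gives the first two: a 2.2-fold higher number from compound 2 to compound 4 (0.33 log units; beyond the scatter) and a 2.8-fold higher number from compound 1 to compound 4 (0.44 log units; beyond the scatter), both modest and both toward weaker inhibition. The third step, a 2.0-fold higher number from compound 3 to compound 4 (0.30 log units; within the scatter), stays within the scatter, so compound 3 goes against this pattern, and the group on this benzyl position has so far moved the number only slightly. Nothing measured here bears on what lies behind these steps.

The compounds shown do not separate the presence of chlorine from the presence of two groups on the phenyl ring. On these data alone, whether a phenyl ring with a single chlorine, a methoxy group or a carboxylic acid would stay close to compound 3 or to compound 4 remains open.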